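The source may report more compounds than this note shows. Statements on the series, on what has been measured and on what is new or still open speak of the compounds shown alone.

Series notes. The shared core of compound 3 `O=C(Nc1c(C(O)(C(F)(F)F)C(F)(F)F)ccc2ccccc12)c1cc(Cl)cc(Cl)c1` carries an amide on the naphthalene-type nitrogen; in an assay on LtK cells with ATP-sensitive inward rectifier potassium channel 11 (Homo sapiens) as the target (a higher number here means that more compound is needed for the effect, a lower number that less compound is needed), compound 3 gives 306 nM, the second highest of the three numbers in hand. Compound 1 `CCCC(=O)Nc1c(C(O)(C(F)(F)F)C(F)(F)F)ccc2ccccc12` gives 131 nM in this assay, and compound 2 `O=C(Nc1c(C(O)(C(F)(F)F)C(F)(F)F)ccc2ccccc12)C1CCCC1` gives 495 nM. The steps among them are small: a 2.3-fold higher number from compound 1 to compound 3 (0.37 log units; beyond the scatter) and a 3.8-fold higher number from compound 1 to compound 2 (0.58 log units; beyond the scatter), while a 1.6-fold lower number from compound 2 to compound 3 (0.21 log units; within the scatter).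

Compound 4 `O=C(Nc1c(C(O)(C(F)(F)F)C(F)(F)F)ccc2ccccc12)c1cnco1` differs from compound 3 by 1,3-oxazol-5-yl in place of 3,5-dichlorophenyl on a carbonyl carbon. Going by the values given here, none of the measured steps exchanges one aromatic ring for another; the steps that bear on it are the exchanges at the carbonyl carbon, a 2.3-fold higher number from compound 1 to compound 3 (0.37 log units; beyond the scatter) and a 3.8-fold higher number from compound 1 to compound 2 (0.58 log units; beyond the scatter), both modest, and a 1.6-fold lower number from compound 2 to compound 3 (0.21 log units; within the scatter), within the scatter. Together they show that changes at this position have so far moved this assay only modestly. Among the compounds with values here, a five-membered aromatic ring with two hetero atoms and two hydrogen-bond acceptors has no precedent among the three compounds, so a step of modest size is expected, with a higher number somewhat more likely than a lower one; the expected step is a 1.6-fold higher number from compound 3 to compound 4 (0.21 log units; within the scatter). Compound 4 is therefore estimated at 500 nM, with a range from 150 nM to 1700 nM.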

Compound 4, half-maximal effective concentration: 24 nM
For compound 4 the middle estimate is 21-fold (1.32 log units) above the measured one, outside the stated range (below it).
By their numbers in this assay, from the lowest: compound 4; then compound 1; then compounds 3 and 2 (each within the scatter of the next).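

In this assay the group on the carbonyl carbon proves able to move the number much further than the earlier exchanges, which stayed modest or within the scatter: 1,3-oxazol-5-yl in place of 3,5-dichlorophenyl gives a large step (a 13-fold lower number from compound 3 to compound 4 (1.11 log units; beyond the scatter)), and in place of cyclopentyl another large one (a 21-fold lower number from compound 2 to compound 4 (1.31 log units; beyond the scatter)). Going by these compounds alone, in place of propyl, the group with the lowest number among the earlier compounds, the step is modest but still beyond the scatter (a 5.5-fold lower number from compound 1 to compound 4 (0.74 log units; beyond the scatter)), so compound 4 now has the lowest number of the series and a lower number is no longer tied to the small chain of compound 1. The position therefore tolerates a five-membered aromatic ring with 2 hetero atoms, and this ring does better here than the six-membered aromatic ring of carbon only, the propyl chain and the cyclopentyl ring.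

Still open, as far as these compounds go, is whether the step belongs to this particular ring or would also appear with a 1,3-thiazol-5-yl, a furan-2-yl or a pyridin-3-yl group at the same carbonyl carbon. Nothing shown here gives a reason for the size of the step.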